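Methyl in Place of Chloro on the Aromatic Carbon

The source may report more compounds than this note shows. Statements on the series, on what has been measured and on what is new or still open speak of the compounds shown alone.

Compound 1 `O=C(/C=C/c1ccc2c(c1)B(O)OC2)c1ccccc1` and compound 2 `O=C(/C=C/c1ccc2c(c1)B(O)OC2)c1ccc(Cl)cc1` share one core. In a functional assay on HCT-116 cells (Homo sapiens) for cytotoxicity, read by MTT assay, with a stated time of 48 h (a higher number here means a weaker inhibitor, a lower number a stronger inhibitor), compound 1 gives 6100 nM and compound 2 gives 9300 nM; a 1.5-fold higher number from compound 1 to compound 2 (0.18 log units; within the scatter), so the two sit together. Compound 2 holds the highest of the two numbers. Compound 3 `Cc1ccc(C(=O)/C=C/c2ccc3c(c2)B(O)OC3)cc1` differs from compound 2 by methyl in place of chloro on an aromatic carbon. Among the compounds with values here, no measured step swaps these two groups; the only step known exchanges hydrogen for chloro and stays within the scatter. For compound 3 the expected step is therefore a 1.2-fold lower number from compound 2 to compound 3 (0.07 log units; within the scatter), and its estimated value is 8000 nM, between 4000 nM and 16000 nM.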

Compound 3, half-maximal inhibitory concentration: 10500 nM
For compound 3 the middle estimate is 1.3-fold (0.12 log units) below the measured one; low and high end bracket the measured number.
By their numbers in this assay, from the lowest: compounds 1, 2 and 3 (each within the scatter of the next).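

In this assay the swap of chloro for methyl adds a second change at this place that stays within the scatter (a 1.1-fold higher number from compound 2 to compound 3 (0.05 log units; within the scatter)), and methyl in place of hydrogen does too (a 1.7-fold higher number from compound 1 to compound 3 (0.24 log units; within the scatter)). Hydrogen, chloro and methyl on this aromatic carbon, para to a large group, therefore cannot be told apart here. No evidence bears on why these numbers sit together. Still open, on these data alone, is whether an amine, a carboxylic acid or a longer chain at this place would also stay within the scatter, and whether the same swaps would read alike elsewhere on the shared core.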